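Swapping the Terminal Ring: Does the Maximal Response Hold?

The source may report more compounds than this note shows. Statements on the series, on what has been measured and on what is new or still open speak of the compounds shown alone.

Two sulfonamides share a core and differ only in the ring hanging from the far end. Compound 1 `COc1ccc(N2C[C@@H](C)N[C@@H](C)C2)cc1NS(=O)(=O)c1ccc(-c2cccs2)cc1` carries a thiophen-2-yl group there, and in a functional assay for agonist activity at growth hormone secretagogue receptor type 1 (Homo sapiens), read by FLIPR (a lower number here means a smaller maximal response, a higher number a larger maximal response), compound 1 gives 1. Compound 2 `COc1ccc(N2C[C@@H](C)N[C@@H](C)C2)cc1NS(=O)(=O)c1ccc(-c2ccc(C)o2)cc1` carries a 5-methylfuran-2-yl group instead, and in this assay compound 2 gives 1. The step of no change at the digits printed from compound 1 to compound 2 (within the scatter) shows that exchanging one five-membered ring for another left the maximal response untouched, so compound 2 stands level with compound 1.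

Compound 3 `COc1ccc(N2C[C@@H](C)N[C@@H](C)C2)cc1NS(=O)(=O)c1ccc(Oc2ccccc2)cc1` makes a larger change: phenoxy in place of 5-methylfuran-2-yl on an aromatic carbon. For the measured compounds named here, only the step from compound 1 to compound 2 bears on this, and it was flat, so no shift beyond the scatter in this assay is expected, with perhaps a small drop allowed for the different ring. Compound 3 is therefore estimated at 0.95, in a range from 0.75 to 1.05, which means an expected step of a number 0.050 lower from compound 2 to compound 3 (within the scatter).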

Compound 3, intrinsic activity: the largest response reached, as a fraction of the reference agonist's: 0.9
The estimate for compound 3 lay 0.050 above the measured number; the measured number falls inside the stated range.
By their numbers in this assay, from the lowest: compounds 3, 1 and 2 (each within the scatter of the next).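

Phenoxy is a larger change than the swap between the two five-membered rings, and this assay still does not separate it from them: the result is a number 0.10 lower from compound 2 to compound 3 (within the scatter), and likewise a number 0.10 lower from compound 1 to compound 3 (within the scatter). At this place, para to a large group, a six-membered aromatic ring of carbon only therefore serves within the scatter as well as the five-membered rings of compound 1 and compound 2. No measurement is at hand that would explain this tolerance.

On these data alone, all three compounds carry an aromatic ring at this place, so it remains open whether the maximal response would hold with an amine, a carboxylic acid or a plain alkyl chain there. Intrinsic activity also tells only how large the response becomes, not how much compound is needed to reach it.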